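A few compounds are considered here, and "the series" means these few. Any claim that something is new, unique, unknown or untested is made for them only; others in the source may bear on it.

Measured so far in a functional assay on A549 cells (Homo sapiens) for antiproliferative activity, read by MTT assay, with a stated time of 48 h; on this read-out lower numbers stand for stronger inhibition and higher numbers for weaker inhibition:
- Compound 1 `C/C(=C\CC/C(C)=C/CC[C@@H]1[C@@]2(C)CCC(=O)C(C)(C)[C@H]2CC[C@@]1(C)O)CC/C=C(\C)C(=O)OCc1cn(-c2ccc([N+](=O)[O-])cc2)nn1`: > 150000 nM, a limit
- Compound 2 `COc1ccccc1-n1cc(COC(=O)/C(C)=C/CC/C(C)=C/CC/C(C)=C/CC[C@@H]2[C@@]3(C)CCC(=O)C(C)(C)[C@H]3CC[C@@]2(C)O)nn1`: > 150000 nM, a limit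

Compound 2 has no number on this read-out, only the limit > 150000 nM. Compound 1 offers no firmer reference, and the pair stands at the limit of > 150000 nM in this assay, at which 2 of the 2 values shown sit.

Compound 3 `C/C(=C\CC/C(C)=C/CC[C@@H]1[C@@]2(C)CCC(=O)C(C)(C)[C@H]2CC[C@@]1(C)O)CC/C=C(\C)C(=O)OCc1cn(-c2ccc(C(F)(F)F)cc2)nn1` carries 4-(trifluoromethyl)phenyl in place of 2-methoxyphenyl on an aromatic nitrogen.

Going by the values given here, the one measured step that bears on this is a step that the two limits leave unreadable from compound 1 to compound 2, which is another exchange on that aromatic nitrogen. That step gives no size to carry over, so no step beyond the scatter is expected in this assay, and no direction can be favoured. The expected change is a number no higher from compound 2 to compound 3 (the limit leaves the size open). For compound 3 the estimated value is 150000 nM, with an expected range from 60000 nM to 300000 nM, and a report of the limit alone is the likeliest outcome.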

Compound 3, half-maximal inhibitory concentration: > 150000 nM
Compound 3 was reported as a limit; the forecaster's own chance of this, stated with the estimate: 80%; the middle value sits exactly at the limit.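

In this assay compound 3 gives > 150000 nM, a limit and not a number. Going by these compounds alone, no step among compound 1, compound 2 and compound 3 can be read, since all three share one limit: the limit of > 150000 nM in this assay, at which 3 of the 3 values shown sit. The compounds shown leave open whether the group on the aromatic nitrogen affects activity at all.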